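Compound 4 and the assay limit

This account rests on a few compounds, and the source may have more. Where it says the series, first, only, none or still open, it means among the compounds named here.

Measured in a physicochemical assay for lipophilicity, at pH 7.4; a higher number here means a more lipophilic compound, a lower number a more polar compound:
- compound 1 `Cc1cc(NC(=O)CC(C)(C)C)nn1Cc1cc(Cl)ccc1OCc1ccccc1`: > 3.7
- compound 2 `Cc1cc(NC(=O)C2CCCO2)nn1Cc1cc(Cl)ccc1OCc1ccccc1`: > 3.7
- compound 3 `Cc1cc(NC(=O)c2ccccc2)nn1Cc1cc(Cl)ccc1OCc1ccccc1`: > 3.7

Among the measured compounds shown here, the series so far offers no number, only (the limit of > 3.7 in this assay, at which 3 of the 3 values shown sit). Compound 3 gives > 3.7, which is a limit and not a number.

Compound 4 `Cc1cc(NC(=O)O[C@H]2CCOC2)nn1Cc1cc(Cl)ccc1OCc1ccccc1` keeps the core of compound 3 and carries (oxolan-3-yl)oxy in place of phenyl on a carbonyl carbon.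

For the measured compounds named here, three measured steps bear on this change: a step that the two limits leave unreadable from compound 2 to compound 3, a step that the two limits leave unreadable from compound 1 to compound 3 and a step that the two limits leave unreadable from compound 1 to compound 2. None of them has a readable size, so they give neither a size nor a direction for the change at hand. The closest guide is compound 2, which carries oxolan-2-yl on a carbonyl carbon and whose > 3.7 is a limit. On that basis, no step beyond the scatter is expected in this assay, and the expected step is a number no higher from compound 3 to compound 4 (the limit leaves the size open). The estimate for compound 4 is 3.7, with an expected range of 3.2 to 4.2.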

Compound 4, distribution coefficient: 2.7
Beside the measured number, compound 4's estimate is 1.00 log units above it, outside the stated range (below it).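

Among the compounds shown here, compound 4 is the first to give a number in this assay, while the other compounds remain at a limit: the limit of > 3.7 in this assay, at which 3 of the 4 values shown sit. On the carbonyl carbon, (oxolan-3-yl)oxy in place of phenyl gives a number at least 1.00 log units lower from compound 3 to compound 4 (beyond the scatter), and in place of neopentyl it gives a number at least 1.00 log units lower from compound 1 to compound 4 (beyond the scatter). Even the group closest to it, oxolan-2-yl, stays at the limit, with a number at least 1.00 log units lower from compound 2 to compound 4 (beyond the scatter), so an oxygen-containing five-membered ring at this position does not alone bring the read-out to a number.

Going by these compounds, the steps among compound 1, compound 2 and compound 3 cannot be read, and the three new steps rest on limits, so their full size stays open. On these data alone, how a carboxylic acid or an amine on this carbonyl carbon would read in this assay also stays open.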